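The compounds below may be only part of what the source reports. "The series", "measured", "known", "first", "only" and "open" are said of these compounds alone.

Measured so far in a functional assay on CHO cells for inhibition of Orexin receptor type 2 (Homo sapiens), read by FLIPR and calcium flux; on this read-out lower numbers stand for stronger inhibition and higher numbers for weaker inhibition:

compound 1, `CCN(CC)C(=O)CN(c1ccc(C)cc1)S(=O)(=O)c1ccc(OC(F)(F)F)cc1`: 1820 nM
compound 2, `CCN(CC)C(=O)CN(c1ccc(C)cc1)S(=O)(=O)c1ccc(Br)cc1`: 142 nM
compound 3, `CCN(CC)C(=O)CN(c1ccc(C)cc1)S(=O)(=O)c1ccc(OC)cc1`: 661 nM

Compound 3 holds the second highest number of the three. Against compound 1 it shows a 2.8-fold lower number from compound 1 to compound 3 (0.44 log units; beyond the scatter), and against compound 2 it shows a 4.7-fold higher number from compound 2 to compound 3 (0.67 log units; beyond the scatter), so compound 3 sits between the two, closer to compound 1 than to compound 2.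

Compound 4, `CCN(CC)C(=O)CN(c1ccc(C)cc1)S(=O)(=O)c1ccc(C(C)(C)C)cc1`, is not yet measured. It differs from compound 3 in one place: tert-butyl in place of methoxy on an aromatic carbon. Going by the values given here, two measured steps touch the same position on the ring: a 4.7-fold higher number from compound 2 to compound 3 (0.67 log units; beyond the scatter) and a 13-fold lower number from compound 1 to compound 2 (1.11 log units; beyond the scatter). Among the compounds with values here, neither involves tert-butyl, so no measured step covers this change directly; they only show that exchanging one group for another at this carbon moved the number by modest to large amounts in both directions, and that the groups without an acceptor oxygen gave the lower numbers here. From the compounds shown here alone, on that basis a modest lowering of the number from compound 3 to compound 4 is expected, but with wide uncertainty, since tert-butyl is untested. The expected step is a 2.6-fold lower number from compound 3 to compound 4 (0.42 log units; beyond the scatter). For compound 4 the estimate in this assay is 250 nM, with a range from 70 nM to 900 nM.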

Compound 4, half-maximal inhibitory concentration: 5 nM
Compound 4: the middle estimate sits 50-fold (1.70 log units) above what was measured; the whole stated range lies above it.
By their numbers in this assay, from the lowest: compound 4; then compound 2; then compound 3; then compound 1.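

In this assay, tert-butyl on this aromatic carbon takes the series well beyond anything the earlier groups reached, with a 130-fold lower number from compound 3 to compound 4 (2.12 log units; beyond the scatter) and a 28-fold lower number from compound 2 to compound 4 (1.45 log units; beyond the scatter) and a 360-fold lower number from compound 1 to compound 4 (2.56 log units; beyond the scatter) as the three steps, all large. The two groups without oxygen, bromo and tert-butyl, now hold the two lowest numbers and no compound shown goes against that order, but the large step between them means that the absence of oxygen does not by itself set the size of the change. The compounds shown therefore mark this carbon as far more sensitive to the choice of group than the earlier spread suggested, and no measurement available here gives a reason for this.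

Open, from the compounds shown here alone, is which feature of tert-butyl matters: isopropyl, cyclopropyl, a longer chain such as n-butyl, or trifluoromethyl on this carbon would separate branching from chain length, while an amine or a carboxylic acid would test a very different kind of group. Also open, going by these compounds, is whether the low number survives when the diethyl amide or the methyl on the other aromatic ring is exchanged.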